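Thiourea Aryl Swap on a Shared Thiophene Carboxamide Core

The source may report more compounds than this note shows. Statements on the series, on what has been measured and on what is new or still open speak of the compounds shown alone.

Measured so far:
Compound 1, `NC(=O)c1c(NC(=O)c2ccccc2F)sc2c1CCN(Cc1c(Cl)cccc1Cl)C2`, 10300 nM
Compound 2, `NC(=O)c1c(NC(=O)c2ccccc2F)sc2c1CCN(Cc1ccc(Cl)cc1Cl)C2`, 13100 nM
Compound 3, `NC(=O)c1c(NC(=O)c2ccccc2Cl)sc2c1CCN(C(=S)Nc1cccc3ccccc13)C2`, 13400 nM

All three compounds were tested in a functional assay on HL-60 cells (Homo sapiens) for antiproliferative activity, with a stated time of 24 h; a lower number here means a stronger inhibitor, a higher number a weaker inhibitor. Compound 1 gives 10300 nM, compound 2 gives 13100 nM and compound 3 gives 13400 nM. Within the data shown here, the only single-point comparison among the measured set is a 1.3-fold higher number from compound 1 to compound 2 (0.10 log units; within the scatter), which changes the benzyl substituent on the ring amine. Compound 3 stands alongside the other two: its number is separated from that of compound 2 and from that of compound 1 by gaps that fall within the scatter, so no ordering among the three can be claimed.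

Compound 4, `NC(=O)c1c(NC(=O)c2ccccc2Cl)sc2c1CCN(C(=S)Nc1ccccc1C(F)(F)F)C2`, has not yet been measured. It differs from compound 3 in one place: 2-(trifluoromethyl)phenyl in place of naphthalen-1-yl on an amide-type nitrogen. Among the measured compounds shown here, no measured pair touches this thiourea aryl group, so the step from compound 3 to compound 4 has no direct precedent here; the single known step, on a different part of the core, stayed within the scatter. With nothing pointing either way, the expected step is a 1.0-fold lower number from compound 3 to compound 4 (0.01 log units; within the scatter), none beyond the scatter. Compound 4 is therefore estimated at 13000 nM, with a range from 4000 nM to 40000 nM.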

Compound 4, half-maximal inhibitory concentration: 10600 nM
The estimate for compound 4 lay 1.2-fold (0.09 log units) above the measured number, within the range that was stated.
By their numbers in this assay, from the lowest: compounds 1, 4, 2 and 3 (each within the scatter of the next).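

In this assay, among these compounds, the first pair to touch the aryl group on the thiourea reads as a 1.3-fold lower number from compound 3 to compound 4 (0.10 log units; within the scatter), with 2-(trifluoromethyl)phenyl in place of naphthalen-1-yl on the amide-type nitrogen. For this one pair, then, going from two six-membered aromatic rings of carbon to one, with trifluoromethyl now on that ring, gives no step beyond the scatter, so the measured numbers do not separate the two groups at this position. No supporting measurement bears on this result, so the data offer no explanation for it.

From the compounds shown here alone, it remains open whether a group of another kind on this nitrogen, such as a phenyl ring carrying a carboxylic acid or an amine, or a plain butyl chain in place of the aryl group, would move the number beyond the scatter. The thiourea compounds also cannot be set directly against the benzyl compounds, compound 1 and compound 2, since they differ in more than one place, which leaves the contribution of the thiourea link itself unresolved.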